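Shrinking a Ring on the Thiocarbonyl Carbon

A few compounds are considered here, and "the series" means these few. Any claim that something is new, unique, unknown or untested is made for them only; others in the source may bear on it.

Three compounds were tested in a functional assay on MDA-MB-435S cells (Homo sapiens) for antiproliferative activity, read by MTT assay, with a stated time of 72 h; on this read-out lower numbers stand for stronger inhibition and higher numbers for weaker inhibition. Compound 1 `COc1ccc2occ(CSC(=S)N3CCCCC3)c(=O)c2c1` gives 930 nM in this assay, the second highest of the three numbers. Compound 3 `O=c1c(CSC(=S)N2CCOCC2)coc2cc(Cl)ccc12` gives 600 nM, a value within the scatter of compound 1, so the two cannot be ranked against each other. Compound 2 `CCN(CC)C(=S)SCc1cc(=O)c2ccc(Cl)cc2o1` gives 23500 nM, a markedly higher number than compound 1, well beyond the scatter.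

Compound 4 `COc1ccc2occ(CSC(=S)N3CCCC3)c(=O)c2c1` has not been measured yet. It differs from compound 1 in one place: pyrrolidin-1-yl in place of piperidin-1-yl on a thiocarbonyl carbon. Among the compounds with values here, since no measured pair shows this change, a step within the scatter is expected, a 1.1-fold higher number from compound 1 to compound 4 (0.03 log units; within the scatter), in no clear direction. Compound 4 is therefore estimated at 1000 nM, with a range from 400 nM to 3000 nM.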

Compound 4, half-maximal inhibitory concentration: 1800 nM
The estimate for compound 4 lay 1.8-fold (0.26 log units) below the measured number; the measured number falls inside the stated range.
By their numbers in this assay, from the lowest: compounds 3, 1 and 4 (each within the scatter of the next, the first and the last beyond it); then compound 2.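

Within the data shown here, this is the first measured pair that isolates the ring on the thiocarbonyl carbon: pyrrolidin-1-yl in place of piperidin-1-yl gives a 1.9-fold higher number from compound 1 to compound 4 (0.29 log units; within the scatter) on the shared core. The two compounds therefore cannot be ranked, and at this position, the five-membered ring serves as well as the six-membered one within the scatter.

From the compounds shown here alone, it remains open whether the seven-membered azepan-1-yl ring or an open-chain dimethylamino group would keep a similar number on this core. No available evidence offers a reason for this result.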